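The source may hold more compounds than are shown below. What is called first, only, known or untested is meant among the compounds shown, and "the series" means these compounds.

In an ADME assay on cells (Hepatocyte, Rattus norvegicus) for metabolic stability (a higher number here means that the compound lasts longer, a lower number that the compound disappears faster), compound 1 (`O=C(C1CCN(c2ncccn2)CC1)N1N=CC[C@H]1c1ccccc1`) gives 0.137 h. That is the lower of the two numbers available, since compound 2 (`N#Cc1ccc(N2CCC(C(=O)N3N=CC[C@H]3c3cc(F)cc(F)c3)CC2)nn1`) gives 2.08 h, a gap beyond the scatter, although these two compounds differ in more than one place. Still unmeasured, compound 3 (`O=C(C1CCN(c2ccncn2)CC1)N1N=CC[C@H]1c1ccccc1`) keeps the core of compound 1 and changes one group: pyrimidin-4-yl in place of pyrimidin-2-yl on an amine nitrogen in a ring. In words, it carries pyrimidin-4-yl in place of pyrimidin-2-yl on an amine nitrogen in a ring. Among the compounds with values here, no measured pair shows what such a swap does in this assay, so the only anchor is compound 1 at 0.137 h, and no change beyond the scatter is expected in either direction. The expected step is a 1.1-fold higher number from compound 1 to compound 3 (0.04 log units; within the scatter). For compound 3 the estimated half-life is 0.15 h, with an expected range from 0.07 h to 0.35 h.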

Compound 3, half-life: < 0.4 h
Compound 3 ended at the assay's limit; the forecaster's own chance of this, stated with the estimate: 3%; the middle value is on the limit's open side.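

In this assay compound 3 gives < 0.4 h, which is a limit of the assay and not a number. No step from compound 1 to compound 3 can therefore be read: the limit of < 0.4 h in this assay, at which 1 of the 3 values shown sits.

As far as these compounds go, whether pyrimidin-4-yl in place of pyrimidin-2-yl shifts the half-life at all remains open.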